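A few compounds are considered here, and "the series" means these few. Any claim that something is new, unique, unknown or untested is made for them only; others in the source may bear on it.

Measured in a functional assay on DU-145 cells (Homo sapiens) for inhibition, read by trypan blue exclusion, with a stated time of 96 h; a higher number here means a weaker inhibitor of growth, a lower number a stronger inhibitor of growth:
- compound 1 `Cc1ccc(CS/C(=C/c2ccc(F)c(C)c2)C(=O)c2ccc(Cl)cc2)cc1`: 25000 nM
- compound 2 `Cc1ccc(CS/C(=C/c2sccc2C)C(=O)c2ccc(Cl)cc2)cc1`: 10000 nM
- compound 3 `O=C(/C(=C\c1cccc(Cl)c1Cl)SCc1ccc(Cl)cc1)c1ccc(Cl)cc1`: 10000 nM

Compound 3 stands level with compound 2 , and these two share the lowest number of the three, while compound 1 reads higher. Compound 4 `Cc1ccc(CS/C(=C/c2cccc(Cl)c2Cl)C(=O)c2ccc(Cl)cc2)cc1` differs from compound 3 in one place: methyl in place of chloro on an aromatic carbon. This is methyl in place of chloro on an aromatic carbon, turning 4-chlorobenzyl into 4-methylbenzyl. Among the compounds with values here, the only measured step, a 2.5-fold lower number from compound 1 to compound 2 (0.40 log units; beyond the scatter), lies elsewhere in the molecule, so it bears only loosely on this change. Within the data shown here, no measured pair isolates this swap, so no shift beyond the scatter is expected. The expected change is no change at the digits printed from compound 3 to compound 4 (within the scatter). For compound 4 the estimated value is 10000 nM, with an expected range of 4000 nM to 25000 nM.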

Compound 4, concentration for 50% growth inhibition: 25000 nM
For compound 4 the middle estimate is 2.5-fold (0.40 log units) below the measured one; the measured number falls inside the stated range.
By their numbers in this assay, from the lowest: compounds 2 and 3 (each within the scatter of the next); then compounds 1 and 4 (each within the scatter of the next).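

Swapping chloro for methyl on this aromatic carbon in this assay gives a 2.5-fold higher number from compound 3 to compound 4 (0.40 log units; beyond the scatter) and so shows that the benzyl end of the molecule, which the earlier step left untouched, responds to a single-atom change. On the 4-methylbenzyl compounds, 2,3-dichlorophenyl gives a 2.5-fold higher number from compound 2 to compound 4 (0.40 log units; beyond the scatter) against 3-methylthiophen-2-yl, whereas no change at the digits printed from compound 1 to compound 4 (within the scatter) is the reading against 4-fluoro-3-methylphenyl. Nothing measured here gives a reason for these results.

From the compounds shown here alone, whether the chloro-to-methyl step holds with the other two groups on the double-bonded carbon stays open. So does how an amine or a carboxylic acid would read on this aromatic carbon.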